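From 4-chlorophenyl to 2,4-dichlorophenyl at the assay limit

The source may report more compounds than this note shows. Statements on the series, on what has been measured and on what is new or still open speak of the compounds shown alone.

In an ADME assay on H9c2 cells (Rattus norvegicus) for cytotoxicity, read by resazurin assay, with a stated time of 72 h (on this read-out higher numbers stand for lower toxicity in this test and lower numbers for higher toxicity in this test), compound 3 (`C/C(=N\Nc1nc(-c2ccc(Cl)cc2)cs1)c1ccc(Cl)c(Cl)c1`) gives > 50000 nM, which is a limit of the assay and not a number. Compound 2 (`C/C(=N\Nc1nc(-c2ccc(F)cc2)cs1)c1ccc(Cl)c(Cl)c1`) gives > 50000 nM, also a limit. Within the data shown here, compound 1 (`C/C(=N\Nc1nc(-c2ccccn2)cs1)c1ccc(Cl)c(Cl)c1`), with pyridin-2-yl, gives 10200 nM, the only actual number so far.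

Compound 4 (`C/C(=N\Nc1nc(-c2ccc(Cl)cc2Cl)cs1)c1ccc(Cl)c(Cl)c1`) is still unmeasured. Its difference from compound 3 is chloro in place of hydrogen on an aromatic carbon, a chloro in place of hydrogen, ortho to a large group and meta to a chloro group.

Among the measured compounds shown here, no measured step makes this exact change. The nearest are the swaps of pyridin-2-yl for 4-fluorophenyl, an at least 4.9-fold higher number from compound 1 to compound 2 (0.69 log units; beyond the scatter), and for 4-chlorophenyl, an at least 4.9-fold higher number from compound 1 to compound 3 (0.69 log units; beyond the scatter), both beyond the scatter. Chloro in place of fluoro gives a step that the two limits leave unreadable from compound 2 to compound 3. Both phenyl compounds sit at the limit, so little change is expected from one more chloro. The expected step is a number no higher from compound 3 to compound 4 (the limit leaves the size open), with nothing beyond the scatter anticipated. For compound 4 the estimated value is 50000 nM, with an expected range from 20000 nM to 120000 nM.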

Compound 4, half-maximal cytotoxic concentration: > 50000 nM
Compound 4: only a limit was reported; the forecaster's own chance of this, stated with the estimate: 60%; the middle value sits exactly at the limit.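

In this assay compound 4 also ends at a limit and not at a number, so the steps from compound 2 and compound 3 to it cannot be read, and any effect of this chloro, ortho to a large group, stays hidden: the limit of > 50000 nM in this assay, at which 3 of the 4 values shown sit.

What can be read is the comparison with pyridin-2-yl, where 2,4-dichlorophenyl gives an at least 4.9-fold higher number from compound 1 to compound 4 (0.69 log units; beyond the scatter), the same kind of step as the two earlier phenyl groups. A chloro at this position therefore brings back none of the toxicity seen with compound 1 within the range of this test.

The compounds shown leave open whether an amine or a carboxylic acid at this position would bring the read-out down to a number. They also leave open what a chloro would do on the pyridin-2-yl ring of compound 1, which gives 10200 nM, a value where a change could be read.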